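This account rests on a few compounds, and the source may have more. Where it says the series, first, only, none or still open, it means among the compounds named here.

Within the data shown here, compound 3 `CC(C)C[C@H](N)c1cc(C(F)(F)F)ccc1N1CCN(C(=O)COc2ccc3ccccc3c2)CC1` is one of three compounds measured in an assay on HEK293 cells for displacement of a labelled ligand from Melanocortin receptor 4 (Homo sapiens) (a lower number here means a stronger inhibitor, a higher number a weaker inhibitor), where compound 3 gives 2000 nM. It stands second highest of the three: compound 1 `CC(C)C[C@H](N)c1cc(C(F)(F)F)ccc1N1CCN(C(=O)COc2cccc(Cl)c2Cl)CC1` gives 2500 nM, and a 1.3-fold lower number from compound 1 to compound 3 (0.10 log units; within the scatter); compound 2 `Cc1cc(CC(C)C(=O)N2CCN(c3ccc(C(F)(F)F)cc3[C@@H](N)CC(C)C)CC2)ccc1Cl` gives 71 nM, and a 28-fold higher number from compound 2 to compound 3 (1.45 log units; beyond the scatter). Compound 4 `Cc1ccc(OCC(=O)N2CCN(c3ccc(C(F)(F)F)cc3[C@@H](N)CC(C)C)CC2)cc1` is not yet measured; it differs from compound 3 by 4-methylphenyl in place of naphthalen-2-yl on an oxygen on a saturated carbon. Among the measured compounds shown here, the one measured step that bears on this change is the swap of the aryl group on the same oxygen, a 1.3-fold lower number from compound 1 to compound 3 (0.10 log units; within the scatter), which stayed within the scatter. The step from compound 3 to compound 4 is therefore expected to be small, no change at the digits printed from compound 3 to compound 4 (within the scatter). In this assay compound 4 is expected to give about 2000 nM, within a range of 600 nM to 7000 nM.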

Compound 4, inhibition constant: 4400 nM
Compound 4: the middle estimate sits 2.2-fold (0.34 log units) below what was measured; the range from low to high includes it.
By their numbers in this assay, from the lowest: compound 2; then compounds 3, 1 and 4 (each within the scatter of the next, the first and the last beyond it).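

Changing the aryl group on this oxygen can shift the number after all: a 2.2-fold higher number from compound 3 to compound 4 (0.34 log units; beyond the scatter) lies beyond the scatter, while a 1.8-fold higher number from compound 1 to compound 4 (0.25 log units; within the scatter) stays within it, so 4-methylphenyl separates from naphthalen-2-yl but not from 2,3-dichlorophenyl. Even so, that shift is small beside the change on the carbonyl carbon, a 62-fold higher number from compound 2 to compound 4 (1.79 log units; beyond the scatter). Nothing shown gives a reason for these steps. Still open, on these data alone, is whether an amine or a carboxylic acid on the aryl group, or a longer chain before the oxygen, would move the number further.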